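This account rests on a few compounds, and the source may have more. Where it says the series, first, only, none or still open, it means among the compounds named here.

Compound 1 `O=C(CCCCC1CCSS1)Nc1ccc(Cl)cn1` gives 7.44%
Compound 2 `O=C(CCCCC(S)CCS)Nc1ccc(Cl)cc1` gives 0.27%
Compound 3 `O=C(CCCCC(S)CCS)Nc1ccc([N+](=O)[O-])c(C(F)(F)F)c1` gives 0.68%

These numbers come from a functional assay on Bel-7402 cells (Homo sapiens) for inhibition, read by MTT assay, with a stated time of 24 h, tested at 1 ug/mL (a lower number here means less inhibition of growth, a higher number more inhibition of growth at the concentration tested), and all lie close together. Compound 2 stands at 0.27% in this company, within the usual scatter of both compound 1 and compound 3, so it cannot be ranked against either.

Compound 4 `COc1ccc(NC(=O)CCCCC(S)CCS)cc1` has not been measured yet. It keeps the rest of compound 2 but carries methoxy in place of chloro on an aromatic carbon. Within the data shown here, no two measured compounds differ in one place only, so the data offer no direct measure of such a swap. The chain of compound 2 also stands in compound 3, with other groups on the ring, and compound 3 gives 0.68% here, which lies within the scatter of compound 2. The step of a number 1.7 percentage points higher from compound 2 to compound 4 (within the scatter) is therefore expected to stay within the scatter in this assay, with no firm direction. For compound 4 the estimated value is 2%, with an expected range from 0% to 9% in this measure.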

Compound 4, percent growth inhibition at one concentration: 3.96%
Beside the measured number, compound 4's estimate is 2 percentage points below it; low and high end bracket the measured number.
By their numbers in this assay, from the lowest: compounds 2, 3, 4 and 1 (each within the scatter of the next).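

Among these compounds, this pair gives the first comparison of two compounds that differ in one place only. In this assay, placing methoxy in place of chloro on an aromatic carbon, para to a large group, gives a number 3.7 percentage points higher from compound 2 to compound 4 (within the scatter), so at this position, two heavy atoms with one hydrogen-bond acceptor can replace a single chlorine without a change that can be told from the usual scatter, and no direction can be claimed for the swap. Nothing measured here bears on the reason for this result.

From the compounds shown here alone, it remains open whether other groups at this position, such as an amine or a carboxylic acid, would shift the number beyond the scatter. Going by these compounds, it is also open whether the same swap would read alike on the core of compound 1.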